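Swapping a fluorophenyl for a methoxyphenyl on the sulfonyl

The source may hold more compounds than are shown below. What is called first, only, known or untested is meant among the compounds shown, and "the series" means these compounds.

The three measured compounds share one core and differ in the two aryl groups around it. Compound 1 `COc1ccc(-c2c(S(=O)(=O)c3ccc(F)cc3)cnc3c(F)cccc23)cc1` gives 2.41 mL/min in an ADME assay on microsomes from liver (Homo sapiens) for metabolic stability, tested at 2.5 uM; on this read-out higher numbers stand for fast clearance and lower numbers for slow clearance. Compound 2 `COc1ccc(S(=O)(=O)c2cnc3c(F)cccc3c2-c2cccc(OC)c2)cc1` gives 2.87 mL/min in this assay. Compound 3 `COc1ccc(-c2c(S(=O)(=O)c3cccc(F)c3)cnc3c(F)cccc23)cc1` gives 2.48 mL/min in this assay; it stands second highest of the three numbers, nearest to compound 1 and furthest from compound 2, both gaps within the scatter. Among the compounds with values here, the only single-point step is a 1.0-fold higher number from compound 1 to compound 3 (0.01 log units; within the scatter), which changes nothing beyond the scatter. Compound 4 `COc1ccc(-c2c(S(=O)(=O)c3ccc(OC)cc3)cnc3c(F)cccc23)cc1` has not yet been measured; it differs from compound 3 by 4-methoxyphenyl in place of 3-fluorophenyl on a sulfonyl sulfur. Within the data shown here, no measured step bears directly on this change, but compound 2, which also carries a methoxyphenyl on a sulfonyl sulfur, gives 2.87 mL/min, close to compound 3. Compound 4 is therefore expected to give 2.8 mL/min, with a range of 1.6 mL/min to 4.8 mL/min. The expected step is a 1.1-fold higher number from compound 3 to compound 4 (0.05 log units; within the scatter), none beyond the scatter.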

Compound 4, intrinsic clearance in a liver preparation (reported as CLH), per the amount of preparation that the assay uses: 2.12 mL/min
For compound 4 the middle estimate is 1.3-fold (0.12 log units) above the measured one; measured number inside the range.
By their numbers in this assay, from the lowest: compounds 4, 1, 3 and 2 (each within the scatter of the next).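

In this assay the step at the sulfonyl sulfur, with a methoxyphenyl now on it in a direct comparison, is a 1.2-fold lower number from compound 3 to compound 4 (0.07 log units; within the scatter) and the change of methoxy in place of fluoro on an aromatic carbon is a 1.1-fold lower number from compound 1 to compound 4 (0.06 log units; within the scatter) so neither fluorophenyl isomer differs from 4-methoxyphenyl at this position beyond the scatter. The aryl group on the shared core is now tested as well: 4-methoxyphenyl in place of 3-methoxyphenyl on an aromatic carbon is a 1.4-fold lower number from compound 2 to compound 4 (0.13 log units; within the scatter) and so this second position also shows no change beyond the scatter. Nothing measured here accounts for these small steps.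

The compounds shown leave open which change, if any, would move this read-out beyond the scatter. On these data alone, whether an amine, a carboxylic acid or a longer chain on the sulfonyl sulfur would do so remains unknown.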